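Lengthening the side chain of a ring amino alcohol

The source may report more compounds than this note shows. Statements on the series, on what has been measured and on what is new or still open speak of the compounds shown alone.

Measured compounds and their values:
compound 1, `CCCCCCCCNC[C@@H]1OC[C@H](N)[C@@H]1O`, 13800 nM
compound 2, `CCCCCCCCNC[C@@H]1OC[C@H](N)[C@H]1O`, 13000 nM

Among these two, compound 1 gives the higher number in a functional assay on PC-3 cells (Homo sapiens) for antiproliferative activity, read by MTT assay, with a stated time of 72 h (a higher number here means a weaker inhibitor, a lower number a stronger inhibitor), while compound 2 sits within the scatter of it, as a 1.1-fold lower number from compound 1 to compound 2 (0.03 log units; within the scatter) shows. That single measured step rests on (the fact that compounds 1 and 2 differ only in the configuration as drawn), and it says nothing about what a change to the side chain might do.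

Compound 3, `CCCCCCCCCCNC[C@@H]1OC[C@H](N)[C@@H]1O`, has not yet been measured. It differs from compound 1 by ethyl in place of hydrogen on a saturated chain carbon, eight bonds along the chain from an amine nitrogen. Among the measured compounds shown here, no measured step bears on this kind of change, so the expectation for compound 3 can only be anchored to compound 1 and must carry a wide range. For compound 3 the value in this assay is estimated at 9000 nM, with a likely span from 2500 nM to 35000 nM. This estimate means a step of a 1.5-fold lower number from compound 1 to compound 3 (0.19 log units; within the scatter), which is expected to stay close to the scatter.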

Compound 3, half-maximal inhibitory concentration: 11900 nM
Compound 3: the middle estimate sits 1.3-fold (0.12 log units) below what was measured; low and high end bracket the measured number.
By their numbers in this assay, from the lowest: compounds 3, 2 and 1 (each within the scatter of the next).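

In this assay, ethyl in place of hydrogen on a saturated chain carbon, eight bonds along the chain from an amine nitrogen, gives a 1.2-fold lower number from compound 1 to compound 3 (0.06 log units; within the scatter), so on this read-out the two compounds cannot be told apart. Among the compounds shown here, the earlier pair differed only in configuration as drawn, whereas this step is the first to touch the side chain, and at this position this one change leaves the number within the scatter. Nothing available accounts for this outcome.

Still open, going by these compounds, is whether a shorter chain, a much longer chain, or a chain ending in a carboxylic acid or a phenyl ring would also stay within the scatter. Also open, on these data alone, is what the same ethyl would do on compound 2, which has the other drawn configuration at one ring carbon.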